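A few compounds are considered here, and "the series" means these few. Any claim that something is new, unique, unknown or untested is made for them only; others in the source may bear on it.

Working notes on the series. The shared core of compound 1 is `C#CCNC1CCc2c(SCc3cccc(F)c3)cccc21`; in an ADME assay on isolated protein for inhibition of Amine oxidase [flavin-containing] B (Homo sapiens) (on this read-out lower numbers stand for stronger inhibition and higher numbers for weaker inhibition), compound 1 gives 11600 nM. Of the three numbers measured, compound 1 has the second highest. Its nearest neighbour is compound 3, `C#CCNC1CCc2c(SCc3ccc(Cl)cc3Cl)cccc21`, which in this assay gives 22300 nM; the two values lie within the scatter of each other, so no order between them can be read. The other measured analogue, compound 2, `C#CCNC1CCc2c(SCCc3ccc(Cl)cc3)cccc21`, gives 920 nM in this assay, a number lower than that of compound 1 by more than the scatter. Going by the values given here, no two of these measured compounds differ in only one place, so no single-change step is available among them, and nothing in the measured set speaks to the change now considered.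

Compound 4, `C#CCNC1CCc2c(SCc3cccc(Br)c3)cccc21`, differs from compound 1 by bromo in place of fluoro on an aromatic carbon. Among the compounds with values here, with no measured step of this kind at hand, the expectation is for a modest shift toward lower numbers, of a size that may or may not clear the scatter, estimated as a 1.8-fold lower number from compound 1 to compound 4 (0.25 log units; within the scatter). On that basis compound 4 is expected to give about 6500 nM in this assay, with a range from 2000 nM to 20000 nM.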

Compound 4, half-maximal inhibitory concentration: > 100000 nM
Compound 4: only a limit was reported; the forecaster's own chance of this, stated with the estimate: 3%; middle value at least 15-fold (1.18 log units) from the limit.
By their numbers in this assay, from the lowest: compound 2; then compounds 1 and 3 (each within the scatter of the next). At a limit, above all of these: compound 4.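

In this assay compound 4 returns only a limit, > 100000 nM, and not a number. Bromo in place of fluoro on an aromatic carbon, meta to a large group, provides the first single-change step in the series, an at least 8.6-fold higher number from compound 1 to compound 4 (0.93 log units; beyond the scatter), so a change at this one position is enough to move the read-out beyond the scatter, in the direction of weaker inhibition rather than stronger. The step is therefore a bound and not a size, and how far compound 4 truly lies from compound 1 stays unknown, since the reading rests on an assay limit: the limit of > 100000 nM in this assay, at which 1 of the 4 values shown sits.

The compounds shown leave open whether chloro, methyl or methoxy in the same place would stay close to compound 1 or fall to a limit like compound 4, and so whether the rise is gradual or abrupt across such groups. They also leave open whether 3-bromophenyl behaves the same way on the longer chain of compound 2, which gives 920 nM, or at other positions of the aromatic ring.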